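This account rests on a few compounds, and the source may have more. Where it says the series, first, only, none or still open, it means among the compounds named here.

Measured so far:
compound 1, `CN1CCN(c2ccc(Nc3ncc4nc(Nc5ccc(F)cc5)n(-c5cccc(NC(=O)CO)c5)c4n3)cc2)CC1`, 7.5 nM
compound 2, `CN1CCN(c2ccc(Nc3ncc4nc(Nc5ccccc5)n([C@H]5CCN(S(=O)(=O)C6CC6)C5)c4n3)cc2)CC1`, 1.6 nM

Of the two compounds measured, compound 1 has the higher number in a functional assay on HCC827 cells (Homo sapiens) for antiproliferative activity, read by MTT assay, with a stated time of 72 h; on this read-out lower numbers stand for stronger inhibition and higher numbers for weaker inhibition; compound 2 sits at a lower number, a gap that goes beyond the usual scatter. Compound 3, `CCOC(=O)CN1CC[C@H](n2c(Nc3ccc(F)cc3)nc3cnc(Nc4ccc(N5CCN(C)CC5)cc4)nc32)C1`, has not yet been measured. It differs from compound 1 in one place: 1-((ethoxycarbonyl)methyl)pyrrolidin-3-yl in place of 3-(((hydroxymethyl)carbonyl)amino)phenyl on an aromatic nitrogen. Within the data shown here, with no measured pair of this kind to lean on, the author expects a modest improvement, by the step of a 2.1-fold lower number from compound 1 to compound 3 (0.33 log units; beyond the scatter), rather than no change. For compound 3 the estimate in this assay is 3.5 nM, with a range from 1.2 nM to 10 nM.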

Compound 3, half-maximal inhibitory concentration: 1810 nM
Compound 3: middle estimate off by 520-fold (2.71 log units), on the low side; measured number outside the range, above it.
By their numbers in this assay, from the lowest: compound 2; then compound 1; then compound 3.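

In this assay, the substituent on this aromatic nitrogen proves highly sensitive: 1-((ethoxycarbonyl)methyl)pyrrolidin-3-yl in place of 3-(((hydroxymethyl)carbonyl)amino)phenyl gives a 240-fold higher number from compound 1 to compound 3 (2.38 log units; beyond the scatter), although both groups have the same heavy-atom count. The change replaces an aromatic ring with a non-aromatic one and leaves no hydrogen-bond donors in the group, and this single step cannot separate these differences. Nothing measured here accounts for the loss. On these data alone, it remains open whether the pyrrolidine ring or its ethyl ester side chain carries the loss. A carboxylic acid or a primary amide in place of the ester would help to separate the two.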